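Ortho-Methoxy in Place of Para-Chloro on the Phenoxy Arm

The source may report more compounds than this note shows. Statements on the series, on what has been measured and on what is new or still open speak of the compounds shown alone.

Compound 3 `COc1ccc(F)cc1CNCCCNc1ccnc2cc(Oc3ccc(Cl)cc3)ccc12` gives 14500 nM in a physicochemical assay for solubility, with a stated time of 18 h, at pH 7.4 (on this read-out lower numbers stand for lower solubility and higher numbers for higher solubility), level with compound 1 `COc1ccc(Oc2ccc3c(NCCCNCc4cc(F)ccc4OC)ccnc3c2)cc1`, which gives 14500 nM; together they are the lowest of the three numbers, and compound 2 `COc1ccc(F)cc1CNCCCNc1ccnc2cc(-c3ccc(C(C)(C)C)cc3)ccc12`, which gives 32000 nM, stands a 2.2-fold lower number from compound 2 to compound 3 (0.34 log units; beyond the scatter) apart. The two measured steps say little beyond this: no change at the digits printed from compound 1 to compound 3 (within the scatter), and a 2.2-fold higher number from compound 1 to compound 2 (0.34 log units; beyond the scatter). The change now considered leads to compound 4 `COc1ccc(F)cc1CNCCCNc1ccnc2cc(Oc3ccccc3OC)ccc12`, which is 2-methoxyphenyl in place of 4-chlorophenyl on an oxygen on an aromatic ring. The step from compound 1 to compound 3 bears most directly on it, since both concern what sits on the phenoxy ring, and it showed no change beyond the scatter; the step from compound 2 to compound 3 concerns a different arm and only sets the span seen so far. On that basis compound 4 is expected to stay close to compound 3, with a step of a 1.1-fold higher number from compound 3 to compound 4 (0.04 log units; within the scatter) that lies within the scatter. The estimate for compound 4 is therefore 16000 nM, with a range from 8000 nM to 32000 nM.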

Compound 4, solubility: 14500 nM
The estimate for compound 4 lay 1.1-fold (0.04 log units) above the measured number; measured number inside the range.
By their numbers in this assay, from the lowest: compounds 1, 3 and 4 (each within the scatter of the next); then compound 2.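

In this assay, the phenoxy arm tolerated both a new substituent and a new substitution pattern: 2-methoxyphenyl in place of 4-chlorophenyl left the number unmoved (no change at the digits printed from compound 3 to compound 4 (within the scatter)), and so did 2-methoxyphenyl in place of 4-methoxyphenyl (no change at the digits printed from compound 1 to compound 4 (within the scatter)). All three phenoxy arms now read alike, and the gap to the 4-(tert-butyl)phenyl arm of compound 2 holds for the new arm too (a 2.2-fold lower number from compound 2 to compound 4 (0.34 log units; beyond the scatter)), with no listed phenoxy compound going against this. Nothing measured here explains why these arms read alike.

As far as these compounds go, whether an amine or a carboxylic acid on the phenoxy ring would shift the number remains open. So does whether a longer chain in place of the one joining the shared core to the 5-fluoro-2-methoxybenzyl end would do so.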